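The source may report more compounds than this note shows. Statements on the series, on what has been measured and on what is new or still open speak of the compounds shown alone.

Compound 2 `CSc1ccc2nc(C)cc(OCC(=O)Nc3cc(C)cc(C)c3)c2c1` is one of three measured members of a small series sharing the same core and the same amide-linked aromatic ring with two methyl groups. In a toxicity assay on HepG2 cells (Homo sapiens) for inhibition, read by CellTiter-Glo, with a stated time of 48 h (a higher number here means a weaker inhibitor, a lower number a stronger inhibitor), compound 2 gives > 100000 nM. That is a limit of the assay rather than a number, namely (the limit of > 100000 nM in this assay, at which 1 of the 3 values shown sits). Its nearest measured relative, compound 1 `COc1ccc2nc(C)cc(OCC(=O)Nc3cc(C)cc(C)c3)c2c1`, gives 20000 nM in this assay; the only difference between them is a methylsulfanyl in place of a methoxy on an aromatic carbon, and that change gave an at least 5.0-fold higher number from compound 1 to compound 2 (0.69 log units; beyond the scatter). Compound 3 `COc1ccc2c(OCC(=O)Nc3cc(C)cc(C)c3)cc(C)nc2c1`, which carries the methoxy on a different aromatic carbon of the core, gives 50100 nM in this assay.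

Compound 4 `Cc1cc(C)cc(NC(=O)COc2cc(C)nc3ccc(Cl)cc23)c1` has not yet been measured. It differs from compound 2 by chloro in place of methylsulfanyl on an aromatic carbon. For the measured compounds named here, no measured step swaps in a chloro, so the step already described at this position is the only guide, and it ended at a limit, leaving its true size open. Compound 4 is therefore expected at about 50000 nM, within 15000 nM to 150000 nM. That estimate corresponds to an at least 2.0-fold lower number from compound 2 to compound 4 (0.30 log units; that floor lies within the scatter).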

Compound 4, half-maximal inhibitory concentration: > 100000 nM
Compound 4: only a limit was reported (the forecaster's own chance of this, stated with the estimate: 40%); at least 2.0-fold (0.30 log units) between middle value and limit.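

Chloro in place of methoxy at this position of the shared core gave an at least 5.0-fold higher number from compound 1 to compound 4 (0.69 log units; beyond the scatter). The higher number seen with methylsulfanyl is therefore not tied to that one group: among these compounds, two different replacements for methoxy both move the reading in this assay the same way. The step between compound 2 and compound 4 cannot be read, because each of them stands at a limit of the assay and not at a number: the limit of > 100000 nM in this assay, at which 2 of the 4 values shown sit.

From the compounds shown here alone, how far beyond that limit either compound lies stays unknown, so the order of chloro and methylsulfanyl remains open. Also open is how an amine, a carboxylic acid or a longer chain such as ethoxy would read at this position, since the compounds shown carry none of these groups there.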